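Benzyl ester extension on a cinnamate side chain

A few compounds are considered here, and "the series" means these few. Any claim that something is new, unique, unknown or untested is made for them only; others in the source may bear on it.

Compound 1 `CCCOC(=O)/C=C/c1ccc(NC(=O)C2(NC(=O)c3ccc4c(C5CCCC5)c(-c5ncc(Cl)cn5)n(C)c4c3)CCC2)cc1OCC` gives 0.35 h in an ADME assay (liver) for pharmacokinetics, with Liver microsome (Rattus norvegicus) as the target, using microsomes; on this read-out lower numbers stand for a shorter-lived compound and higher numbers for a longer-lived compound.
Compound 2 `CCOc1cc(NC(=O)C2(NC(=O)c3ccc4c(C5CCCC5)c(-c5ncc(Cl)cn5)n(C)c4c3)CCC2)ccc1/C=C/C(=O)OCC(C)C` gives 1.42 h in this assay.
Compound 3 `CCOc1cc(NC(=O)C2(NC(=O)c3ccc4c(C5CCCC5)c(-c5ncc(Cl)cn5)n(C)c4c3)CCC2)ccc1/C=C/C(=O)OCC(=O)OC` gives 2.08 h in this assay.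

The three measured compounds share one core and differ only in the ester group on the cinnamate side chain. Compound 3 carries the highest number of the three in this assay; its nearest neighbour is compound 2, and the step of a 1.5-fold higher number from compound 2 to compound 3 (0.17 log units; within the scatter) stays within the scatter, whereas the step of a 5.9-fold higher number from compound 1 to compound 3 (0.77 log units; beyond the scatter) lies beyond it. The third measured step, a 4.1-fold higher number from compound 1 to compound 2 (0.61 log units; beyond the scatter), also lies beyond the scatter.

Compound 4 `CCOc1cc(NC(=O)C2(NC(=O)c3ccc4c(C5CCCC5)c(-c5ncc(Cl)cn5)n(C)c4c3)CCC2)ccc1/C=C/C(=O)OCC(=O)OCc1ccc(Cl)cc1` is the next compound and has not yet been measured in this assay. Against compound 3 it shows (4-chlorophenyl in place of hydrogen on a saturated chain carbon bound to an oxygen next to a carbonyl group). For the measured compounds named here, the steps that bear on this change are those at the same ester carbon, a 5.9-fold higher number from compound 1 to compound 3 (0.77 log units; beyond the scatter) and a 1.5-fold higher number from compound 2 to compound 3 (0.17 log units; within the scatter): growing the ester group once raised the number in this assay modestly and once left it within the scatter. Going by the values given here, no measured step adds an aromatic ring at this place, so the expectation for compound 4 rests on the direction of those two steps only. Compound 4 is therefore expected to give about 2.2 h in this assay, between 0.9 h and 5.5 h, and the step of a 1.1-fold higher number from compound 3 to compound 4 (0.02 log units; within the scatter) is expected to fall within the scatter.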

Compound 4, half-life: 11.4 h
For compound 4 the middle estimate is 5.2-fold (0.71 log units) below the measured one, outside the stated range (above it).
By their numbers in this assay, from the lowest: compound 1; then compounds 2 and 3 (each within the scatter of the next); then compound 4.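

Placing 4-chlorophenyl on the saturated chain carbon bound to an oxygen next to a carbonyl group moves the number in this assay beyond the scatter (a 5.5-fold higher number from compound 3 to compound 4 (0.74 log units; beyond the scatter)), whereas the earlier step to compound 3 from the isopropyl ester stayed within it, so this end of the ester group still has room to shift the read-out once an aromatic ring enters. For the compounds shown here, the wider steps (an 8.0-fold higher number from compound 2 to compound 4 (0.90 log units; beyond the scatter); a 33-fold higher number from compound 1 to compound 4 (1.51 log units; beyond the scatter)) put compound 4 alone at the top of the four compounds, with every step to the others beyond the scatter, and the second of these is the only step of the set graded large. No evidence at hand bears on what lies behind this rise.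

Going by these compounds, it remains open whether the ring or the chlorine accounts for the step, which a plain benzyl ester at this place would help to separate. Also open, on these data alone, are what a free carboxylic acid at the same place would give and whether the order of these four compounds would hold in any read-out other than this assay.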